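The source may report more compounds than this note shows. Statements on the series, on what has been measured and on what is new or still open speak of the compounds shown alone.

Compound 1 `O=S(=O)(Nc1ccc(-c2nc3ccccc3o2)cc1)c1cccs1`: 63000 nM in an assay on cells for inhibition of HSP60/HSP10 (Homo sapiens), with a stated time of 60 min; a lower number here means a stronger inhibitor, a higher number a weaker inhibitor
Compound 3 `O=S(=O)(Nc1ccc(-c2nc3ccccc3o2)cc1)c1ccc(O)cc1`: 78000 nM
Compound 2 `O=S(=O)(Nc1ccc(-c2nc3ccccc3o2)cc1)c1ccccc1O`: a limit of this assay, > 100000 nM

Of the two numbers, compound 3 carries the higher, but the step of a 1.2-fold higher number from compound 1 to compound 3 (0.09 log units; within the scatter) lies within the scatter. Compound 2 sits only at the limit of this assay, so the step of an at least 1.2-fold lower number from compound 2 to compound 3 (0.10 log units; that floor lies within the scatter) gives a floor that also lies within the scatter, as does an at least 1.5-fold higher number from compound 1 to compound 2 (0.20 log units; that floor lies within the scatter). Compound 4 `Cc1ccccc1S(=O)(=O)Nc1ccc(-c2nc3ccccc3o2)cc1` differs from compound 3 by 2-methylphenyl in place of 4-hydroxyphenyl on a sulfonyl sulfur. Within the data shown here, no measured step brings a 2-methylphenyl onto the sulfonyl sulfur; the steps that touch this position all stay within the scatter, so in this assay no step beyond the scatter is expected from compound 3 to compound 4, a 1.0-fold lower number from compound 3 to compound 4 (0.02 log units; within the scatter). Compound 4 is therefore estimated at 75000 nM, within 30000 nM to 190000 nM.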

Compound 4, half-maximal inhibitory concentration: 85000 nM
For compound 4 the middle estimate is 1.1-fold (0.05 log units) below the measured one, within the range that was stated.
By their numbers in this assay, from the lowest: compounds 1, 3 and 4 (each within the scatter of the next). At a limit, above all of these: compound 2.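

In this assay, 2-methylphenyl in place of 4-hydroxyphenyl on a sulfonyl sulfur gives a 1.1-fold higher number from compound 3 to compound 4 (0.04 log units; within the scatter), and 2-methylphenyl in place of thiophen-2-yl gives a 1.3-fold higher number from compound 1 to compound 4 (0.13 log units; within the scatter). A group of carbon only thus stays within the scatter of both a hydroxy-bearing ring and the thiophen-2-yl group. Methyl in place of hydroxy on an aromatic carbon gives only a floor: an at least 1.1-fold lower number from compound 2 to compound 4 (0.07 log units; that floor lies within the scatter).

As far as these compounds go, whether an amine or a carboxylic acid on this ring would give a step beyond the scatter stays open. So does the effect of a longer chain in place of the methyl.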